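Hydrogen in place of methyl on the anilino ring of compound 3

This account rests on a few compounds, and the source may have more. Where it says the series, first, only, none or still open, it means among the compounds named here.

Of the compounds shown here, three have been measured in a functional assay on HepG2 cells (Homo sapiens) for antiproliferative activity, read by CCK-8 assay, with a stated time of 72 h, tested at 8 uM; on this read-out lower numbers stand for a weaker effect and higher numbers for a stronger effect at the one concentration tested. Compound 1 `COC(CCn1cnc2c(NCc3ccc(C(=O)Nc4ccccc4N)cc3)nc(Cl)nc21)OC` gives 34.2%, compound 2 `CC(C)n1cnc2c(Nc3ccccc3)nc(NCOCc3ccc(C(=O)Nc4ccccc4N)cc3)nc21` gives 50.2%, and compound 3 `Cc1ccc(Nc2nc(Cl)nc3c2ncn3Cc2ccc(C(=O)Nc3ccccc3N)cc2)cc1` gives 82%. Compound 3 therefore stands highest of the three numbers; its nearest neighbour is compound 2, which lies beyond the scatter below it, and compound 1 lies further below still, also beyond the scatter. Among the compounds with values here, compounds 1 and 2 differ from compound 3 in several places at once, so no single step between measured compounds is available.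

Compound 4 `Nc1ccccc1NC(=O)c1ccc(Cn2cnc3c(Nc4ccccc4)nc(Cl)nc32)cc1` differs from compound 3 in one place only: hydrogen in place of methyl on an aromatic carbon. Read one bond further out, this is 4-methylphenyl to phenyl, or (4-methylphenyl)amino to anilino.

Within the data shown here, since no measured pair isolates this change, the expectation rests on compound 3 alone and on the size of the change. A step of a number 10 percentage points lower from compound 3 to compound 4 (within the scatter) in this assay is expected, a small decrease that may well stay within the scatter. Compound 4 is estimated to give 72%, with a range from 50% to 88%.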

Compound 4, a percentage reported as inhibition, at one concentration (the size of the read-out at that concentration, not a potency): 74.8%
For compound 4 the middle estimate is 2.8 percentage points below the measured one, and the stated range covers the measured number.
By their numbers in this assay, from the lowest: compound 1; then compound 2; then compounds 4 and 3 (each within the scatter of the next).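

In this assay, within the data shown here, the change from 4-methylphenyl to phenyl gives a number 7.2 percentage points lower from compound 3 to compound 4 (within the scatter) and is the first step in this set that isolates a single place. It shows that the methyl on this aromatic carbon, para to a large group, is not required for a read-out of this size, since compound 4 still gives 74.8% at the one concentration tested. Nothing on hand offers an explanation for this result, and no separate measurement bears on it.

The compounds shown leave open whether a different group on this carbon, such as a methoxy group, a chlorine atom, a primary amine, a carboxylic acid or a longer alkyl chain, would move the read-out beyond the scatter, since only methyl and hydrogen are compared here. They also leave open whether the same exchange would give a step of similar size on a compound with other substituents on the shared core, and how compound 3 and compound 4 would compare at other concentrations.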